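A few compounds are considered here, and "the series" means these few. Any claim that something is new, unique, unknown or untested is made for them only; others in the source may bear on it.

Measured compounds:
- compound 1, `Cc1cc(SC(C)C)c(S(C)(=O)=O)cc1C(=O)N=C(N)N`: 12 nM
- compound 2, `CCOc1cc(C)c(C(=O)N=C(N)N)cc1S(C)(=O)=O`: 19 nM

Both compounds were tested in a functional assay for inhibition of sodium/hydrogen exchanger (Oryctolagus cuniculus); on this read-out higher numbers stand for weaker inhibition and lower numbers for stronger inhibition. Compound 1 gives 12 nM in this assay, and compound 2 gives 19 nM. These two share a core and differ only in one aromatic substituent, ethoxy in place of isopropylsulfanyl; the step of a 1.6-fold higher number from compound 1 to compound 2 (0.20 log units; within the scatter) shows that this exchange left the read-out essentially where it was. Compound 2 thus stands within the scatter of compound 1, and no order can be drawn between the two.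

Compound 3, `Cc1cc(Oc2ccccc2Cl)c(S(C)(=O)=O)cc1C(=O)N=C(N)N`, has not yet been measured. It differs from compound 2 by 2-chlorophenyl in place of ethyl on an oxygen on an aromatic ring. Within the data shown here, the only step on record, from compound 1 to compound 2, touched the same position and was within the scatter, but it exchanged a small group for another small group, whereas here a ring enters. That single step gives no sign of a large shift, so the expected step of a 1.3-fold higher number from compound 2 to compound 3 (0.12 log units; within the scatter) is small, with a wide range to allow for the larger group. Compound 3 is therefore estimated at 25 nM in this assay, expected between 7 nM and 90 nM.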

Compound 3, half-maximal inhibitory concentration: 14 nM
Beside the measured number, compound 3's estimate is 1.8-fold (0.25 log units) above it; the range from low to high includes it.
By their numbers in this assay, from the lowest: compounds 1, 3 and 2 (each within the scatter of the next).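

Changing this position on the shared core need not shift the read-out, even when the new group is much bigger than the old one. Among these compounds, the earlier pair exchanged only one small group for another, whereas here 2-chlorophenyl, with its six-membered aromatic ring and its chlorine, takes the place of ethyl on the oxygen on the aromatic ring, and in this assay the step of a 1.4-fold lower number from compound 2 to compound 3 (0.13 log units; within the scatter) stays inside the usual variation between repeats. Compared with the sulfur-linked group, the step of a 1.2-fold higher number from compound 1 to compound 3 (0.07 log units; within the scatter) is just as small, so isopropylsulfanyl, ethoxy and 2-chlorophenoxy cannot be ranked, and no measurement on hand accounts for this tolerance of such different groups.

On these data alone, what would finally push the number clearly up or down at this position remains open, for instance an amine or a carboxylic acid in place of these groups, or a longer chain on the oxygen. The part played by the chlorine also stays unsettled, and a plain phenyl on the same oxygen would be the direct comparison with compound 3.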